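Cytotoxicity of a thiazole series before the sulfonamide analogue

This account rests on a few compounds, and the source may have more. Where it says the series, first, only, none or still open, it means among the compounds named here.

Compound 1: `Cc1cc(Br)cc(OC(c2ccc(Cl)cc2)c2cnc(NC(=O)OC(C)(C)C)s2)c1` — > 50000 nM in an ADME assay on HepG2 2.2.15 cells (Homo sapiens) for cytotoxicity; a lower number here means that less compound is tolerated, a higher number that more compound is tolerated
Compound 2: `CC(C)(C)OC(=O)Nc1ncc(C(Oc2ccc(Cc3ccccc3)cc2)c2ccc(Cl)cc2)s1` — > 50000 nM in this assay
Compound 3: `COC(=O)CCCCNc1ncc(C(Oc2ccc3cc(Br)ccc3c2)c2ccc(Cl)cc2)s1` — "not toxic" (no number reported) in this assay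

In this assay compound 1 sits at a limit of the assay, > 50000 nM. For compound 2 the same limit, > 50000 nM, is all that is known. Compound 3 carries no number at all, only the report "not toxic" (no number reported), which places it alongside the other two rather than apart from them; the limit of > 50000 nM in this assay, at which 2 of the 3 values shown sit, describes where the series stands.

Compound 4, `Cc1ccc(C)c(S(=O)(=O)Nc2ncc(C(Oc3ccc4cc(Br)ccc4c3)c3ccc(Cl)cc3)s2)c1`, has not yet been measured. It differs from compound 3 by (2,5-dimethylphenyl)sulfonyl in place of 4-(methoxycarbonyl)butyl on a nitrogen on an aromatic ring. With no step shown among the measured compounds, no change beyond the usual scatter is expected in this assay. Compound 4 is therefore estimated at 50000 nM, with a range from 20000 nM to 100000 nM.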

Compound 4, half-maximal cytotoxic concentration: > 50000 nM
Compound 4 gave a limit, no number (the forecaster's own chance of this, stated with the estimate: 75%); the middle value lies on the limit itself.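

Compound 4 gives only a limit, > 50000 nM, and compound 3 has no number, so no step can be read between them. The compounds shown leave open at what concentration any of them becomes cytotoxic in this assay.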